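Swapping a Phenylsulfonyl for a Fluorophenyl Ketone

The source may report more compounds than this note shows. Statements on the series, on what has been measured and on what is new or still open speak of the compounds shown alone.

Compound 1 `OC1CN(CCCOc2ccccc2)CCc2cc(OCc3ccccc3)ccc21`: in an assay for displacement of a labelled ligand from Sigma non-opioid intracellular receptor 1 (Cavia porcellus), read by scintillation counting, with a stated time of 180 min (a higher number here means a weaker inhibitor, a lower number a stronger inhibitor), compound 1 gives 193 nM.
Compound 2 `O=S(=O)(CCCN1CCc2cc(OCc3ccccc3)ccc2C(O)C1)c1ccccc1`: compound 2 gives 349 nM.
Compound 3 `O=C(c1ccccc1)N1CCC(N2CCc3cc(OCc4ccccc4)ccc3C(O)C2)CC1`: compound 3 gives > 1000 nM, which is a limit of the assay, not a number.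

Compound 2 holds the higher of the two numbers, yet the step of a 1.8-fold higher number from compound 1 to compound 2 (0.26 log units; within the scatter) is within the scatter, so the two cannot be ranked. Compound 3 sits at the limit of > 1000 nM in this assay, at which 1 of the 3 values shown sits.

Compound 4 `O=C(CCCN1CCc2cc(OCc3ccccc3)ccc2C(O)C1)c1ccc(F)cc1` differs from compound 2 by (4-fluorophenyl)carbonyl in place of phenylsulfonyl on a saturated chain carbon, three bonds along the chain from an amine nitrogen in a ring. Among the compounds with values here, the only measured step at this place, a 1.8-fold higher number from compound 1 to compound 2 (0.26 log units; within the scatter), changed little, so a step of similar size is expected here: a 1.9-fold lower number from compound 2 to compound 4 (0.29 log units; within the scatter), not beyond the scatter. Compound 4 is estimated at 180 nM, between 60 nM and 550 nM.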

Compound 4, inhibition constant: 293 nM
Beside the measured number, compound 4's estimate is 1.6-fold (0.21 log units) below it, within the range that was stated.
By their numbers in this assay, from the lowest: compounds 1, 4 and 2 (each within the scatter of the next). At a limit, above all of these: compound 3.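

The step to the (4-fluorophenyl)carbonyl group stays small in this assay: a 1.2-fold lower number from compound 2 to compound 4 (0.08 log units; within the scatter). Measured against the phenoxy group, it is also small: a 1.5-fold higher number from compound 1 to compound 4 (0.18 log units; within the scatter). Phenoxy, phenylsulfonyl and (4-fluorophenyl)carbonyl, three different groups at this place on the chain, therefore cannot be ranked, which the single earlier step could not show.

Nothing measured here gives a reason for this flat result. On these data alone, whether an amine, a carboxylic acid or a longer chain at this place would move the number beyond the scatter stays open.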